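Moving the chlorine around the benzyl ring

The source may report more compounds than this note shows. Statements on the series, on what has been measured and on what is new or still open speak of the compounds shown alone.

Of the compounds shown here, three sharing one core have been measured in a functional assay on MDA-MB-231 cells (Homo sapiens) for cytotoxicity, read by MTT assay, with a stated time of 72 h; on this read-out lower numbers stand for stronger inhibition and higher numbers for weaker inhibition. Compound 1 `CC1CCN(Cc2ccc3nc(NC(=O)N/N=C/c4cn(Cc5ccccc5Cl)c5ccccc45)sc3c2)CC1` gives 1360 nM in this assay. Compound 2 `CN(C)Cc1ccc2nc(NC(=O)N/N=C/c3cn(Cc4ccccc4Cl)c4ccccc34)sc2c1` gives 1180 nM in this assay. Compound 3 `CCN(CC)Cc1ccc2nc(NC(=O)N/N=C/c3cn(Cc4ccc(C(C)(C)C)cc4)c4ccccc34)sc2c1` gives 2120 nM in this assay. Compound 2 carries the lowest of the three numbers, yet its gaps to compound 1 and to compound 3 both lie within the usual scatter, so none of the three can be called more active than another. Among the compounds with values here, the one single-point step among them, a 1.2-fold lower number from compound 1 to compound 2 (0.06 log units; within the scatter), is likewise within the scatter.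

Compound 4 `CN(C)Cc1ccc2nc(NC(=O)N/N=C/c3cn(Cc4cccc(Cl)c4)c4ccccc34)sc2c1` is the next compound in line. It differs from compound 2 in one place: 3-chlorophenyl in place of 2-chlorophenyl on a saturated chain carbon bound to an aromatic nitrogen. Within the data shown here, no measured step touches this part of the molecule; compound 3 carries a different group there, but it also differs in the amine, so its number cannot be read as a step of this kind. Nothing in the measured data therefore points to a change beyond the scatter, and the expected step of a 1.2-fold higher number from compound 2 to compound 4 (0.07 log units; within the scatter) is small and of uncertain direction. Compound 4 is expected to give about 1400 nM in this assay, with a range from 600 nM to 3500 nM.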

Compound 4, half-maximal inhibitory concentration: 1140 nM
The estimate for compound 4 lay 1.2-fold (0.09 log units) above the measured number; the range from low to high includes it.
By their numbers in this assay, from the lowest: compounds 4, 2, 1 and 3 (each within the scatter of the next).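

Within the data shown here, this is the first single-point step at the group on a saturated chain carbon bound to an aromatic nitrogen, and in this assay it is small (a 1.0-fold lower number from compound 2 to compound 4 (0.01 log units; within the scatter)). With dimethylamino held constant, 2-chlorobenzyl and 3-chlorobenzyl, which have the same atoms joined differently, cannot be told apart on this cytotoxicity read-out, so the place of the chlorine on the benzyl ring makes no difference beyond the scatter for this pair. No supporting measurement bears on this result, so the reason for the likeness remains unknown.

On these data alone, it remains open whether a plain benzyl, a fluorobenzyl or a methoxybenzyl group on the same carbon would also fall within the scatter of compound 2 and compound 4. As far as these compounds go, it is equally open whether the likeness of the two chlorobenzyl groups would hold with 4-methylpiperidin-1-yl or morpholine in place of dimethylamino, and compound 3 cannot settle either question, as it differs from compound 2 and compound 4 in both the amine and the benzyl group.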